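Phenyl for Decyl on the Sulfur-Bound Carbon

The compounds below may be only part of what the source reports. "The series", "measured", "known", "first", "only" and "open" are said of these compounds alone.

Measured so far:
compound 1 `CC1(C)CC(=O)C(C(=S)SCc2ccccc2)=C(Nc2ccc(Cl)cc2Cl)C1`: > 50 ug/mL
compound 2 `CCCCCCCCCCCSC(=S)C1=C(Nc2ccc(Br)cc2)CC(C)(C)CC1=O`: > 50 ug/mL

Of the compounds shown here, two have been tested in a functional assay on PBMC cells (Homo sapiens) for inhibition, read by thymidine incorporation, with a stated time of 72 h; a higher number here means a weaker inhibitor, a lower number a stronger inhibitor. Compound 1 `CC1(C)CC(=O)C(C(=S)SCc2ccccc2)=C(Nc2ccc(Cl)cc2Cl)C1` gives only a limit there, > 50 ug/mL. Compound 2 `CCCCCCCCCCCSC(=S)C1=C(Nc2ccc(Br)cc2)CC(C)(C)CC1=O` likewise gives only a limit, > 50 ug/mL. Going by the values given here, compound 2 therefore stands at the limit, and the one other value shown is a limit as well (the limit of > 50 ug/mL in this assay, at which 2 of the 2 values shown sit). Among the compounds with values here, no step between measured compounds can be stated.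

Compound 3 `CC1(C)CC(=O)C(C(=S)SCc2ccccc2)=C(Nc2ccc(Br)cc2)C1` differs from compound 2 by phenyl in place of decyl on a saturated chain carbon bound to a sulfur. Compound 1 already carries the phenyl on the saturated chain carbon bound to a sulfur and in this assay gives a limit, > 50 ug/mL. On that basis compound 3 is expected to show no step beyond the scatter, a step that the limit leaves unreadable from compound 2 to compound 3, and most likely another limit. The estimate for compound 3 is 60 ug/mL, with a range from 20 ug/mL to 150 ug/mL.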

Compound 3, half-maximal inhibitory concentration: > 50 ug/mL
Compound 3: only a limit was reported; the forecaster's own chance of this, stated with the estimate: 80%; the middle value is on the limit's open side.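

Compound 3 gives only a limit in this assay, > 50 ug/mL. No step from compound 2 or compound 1 to compound 3 can be read: the limit of > 50 ug/mL in this assay, at which 3 of the 3 values shown sit.

The compounds shown leave open whether phenyl or decyl on the saturated chain carbon bound to a sulfur, or 4-bromophenyl or 2,4-dichlorophenyl on an amine nitrogen, makes any difference in this assay.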